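From 4-fluorophenyl to 3-chlorophenyl on a shared core

A few compounds are considered here, and "the series" means these few. Any claim that something is new, unique, unknown or untested is made for them only; others in the source may bear on it.

In a functional assay on SGC-7901 cells (Homo sapiens) for inhibition, read by MTT assay, with a stated time of 24 h (on this read-out lower numbers stand for stronger inhibition and higher numbers for weaker inhibition), compound 1 `CC1(C)[C@H]2CC[C@]1(C)N(Cc1cn(-c3ccccc3C#N)nn1)C(=O)C2` gives 260 nM and compound 2 `CC1(C)[C@H]2CC[C@]1(C)N(Cc1cn(-c3ccc(F)cc3)nn1)C(=O)C2` gives 500 nM on the same read-out. These two values lie within the usual scatter of each other, so compound 2 cannot be ranked apart from compound 1. Compound 3 `CC1(C)[C@H]2CC[C@]1(C)N(Cc1cn(-c3cccc(Cl)c3)nn1)C(=O)C2` keeps the shared core but differs from compound 2 at one place 3-chlorophenyl in place of 4-fluorophenyl on an aromatic nitrogen with 3-chlorophenyl in place of 4-fluorophenyl on an aromatic nitrogen. Within the data shown here, the only measured step at that nitrogen is a 1.9-fold higher number from compound 1 to compound 2 (0.28 log units; within the scatter) and it stays within the scatter, so no step beyond the scatter is expected in this assay for this change. Among the measured compounds shown here, no measured compound carries chlorine, so this expectation rests on thin evidence. The expected step is a 1.3-fold lower number from compound 2 to compound 3 (0.10 log units; within the scatter) and remains an estimate. For compound 3 the estimate is 400 nM and the expected range runs between 150 nM and 1000 nM on that read-out.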

Compound 3, half-maximal inhibitory concentration: 510 nM
Beside the measured number, compound 3's estimate is 1.3-fold (0.11 log units) below it, within the range that was stated.
By their numbers in this assay, from the lowest: compounds 1, 2 and 3 (each within the scatter of the next).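

In this assay the change to 3-chlorophenyl gives a 1.0-fold higher number from compound 2 to compound 3 (0.01 log units; within the scatter) and so shows that a chlorine-bearing phenyl ring can stand on this aromatic nitrogen with no readable shift in the number. The wider comparison, a 2.0-fold higher number from compound 1 to compound 3 (0.29 log units; within the scatter), also stays within the scatter, so 2-cyanophenyl, 4-fluorophenyl and 3-chlorophenyl cannot be told apart at this position in this assay. No supporting measurement is available to explain why these groups read alike.

All three compounds carry a substituted phenyl ring at this nitrogen, so these results cannot show whether the flat picture extends beyond that kind of group. As far as these compounds go, it remains open how an amine or a carboxylic acid on the ring would read, or a plain butyl chain in place of the ring.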